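Two Naphthalene Sulfonamides Measured, a Third Awaited

This account rests on a few compounds, and the source may have more. Where it says the series, first, only, none or still open, it means among the compounds named here.

Compound 2, `Cc1noc(NS(=O)(=O)c2cccc3c(CN(C)C)cccc23)c1C`, 2800 nM
Compound 1, `Cc1noc(NS(=O)(=O)c2cccc3c(Cl)cccc23)c1C`, 24000 nM

For the measured compounds named here, in an assay on VSM-A10 cells for antagonist activity at Endothelin-1 receptor (Rattus norvegicus) (on this read-out lower numbers stand for stronger inhibition and higher numbers for weaker inhibition), compound 2 gives the lowest of the two numbers so far; its nearest neighbour is compound 1, which differs by an 8.6-fold lower number from compound 1 to compound 2 (0.93 log units; beyond the scatter). Compound 3, `CNc1cccc2c(S(=O)(=O)Nc3onc(C)c3C)cccc12`, differs from compound 2 by methylamino in place of (dimethylamino)methyl on an aromatic carbon. Going by the values given here, no measured step covers this exact change; the only step known, from chloro to (dimethylamino)methyl, was modest. A modest step of uncertain direction is therefore expected for compound 3, a 1.8-fold higher number from compound 2 to compound 3 (0.25 log units; within the scatter). Compound 3 is estimated at 5000 nM, within 1200 nM to 20000 nM.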

Compound 3, half-maximal inhibitory concentration: 130 nM
Estimate against measurement, compound 3: 38-fold (1.59 log units) above, outside the stated range (below it).
By their numbers in this assay, from the lowest: compound 3; then compound 2; then compound 1.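

In this assay, this aromatic carbon proved far more sensitive than the first pair suggested. Methylamino in place of (dimethylamino)methyl gives a much larger change (a 22-fold lower number from compound 2 to compound 3 (1.33 log units; beyond the scatter)), and methylamino in place of chloro gives the largest change seen so far (a 180-fold lower number from compound 1 to compound 3 (2.27 log units; beyond the scatter)), which places compound 3 lowest of the three. Nothing available accounts for these steps.

The compounds shown leave open whether the gain belongs to methylamino itself, since this change alters both the group's size and its hydrogen-bond donor count. A plain amine, ethylamino or dimethylamino on the same carbon would help to separate these.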